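Amino in Place of Chloro on the Shared Core

This account rests on a few compounds, and the source may have more. Where it says the series, first, only, none or still open, it means among the compounds named here.

Compound 1 `Nc1nn(C(=O)Nc2ccc(Cc3ccccc3)cc2)c2ccccc12`: 17200 nM
Compound 2 `Nc1nn(C(=O)Nc2ccc(Cc3ccccc3)cc2)c2ccc(Cl)cc12`: 13300 nM

Of the compounds shown here, two have been measured in a functional assay on Hs-578T cells (Homo sapiens) for antiproliferative activity, read by sulforhodamine B assay, with a stated time of 48 h; on this read-out higher numbers stand for weaker inhibition of growth and lower numbers for stronger inhibition of growth. Compound 2 stands with compound 1 rather than apart from it: the step of a 1.3-fold lower number from compound 1 to compound 2 (0.11 log units; within the scatter) lies within the scatter, so the two compounds are not told apart by these numbers, and neither can be called the stronger.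

Compound 3 `Nc1ccc2c(c1)c(N)nn2C(=O)Nc1ccc(Cc2ccccc2)cc1` has not yet been measured. It differs from compound 2 in one place: amino in place of chloro on an aromatic carbon. For the measured compounds named here, the only measured step that bears on this position is a 1.3-fold lower number from compound 1 to compound 2 (0.11 log units; within the scatter), where hydrogen gave way to chloro and the number hardly moved. Going by the values given here, no measured step puts an amino at that position, so there is no direct precedent for the entering group, only the observation that this position tolerated a change without a shift beyond the scatter.

On that basis the step of a 1.1-fold higher number from compound 2 to compound 3 (0.05 log units; within the scatter) is expected to stay within the scatter, in no clear direction. For compound 3 the estimate in this assay is 15000 nM, with a range from 6000 nM to 40000 nM.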

Compound 3, concentration for 50% growth inhibition: 17300 nM
Compound 3: the middle estimate sits 1.2-fold (0.06 log units) below what was measured, within the range that was stated.
By their numbers in this assay, from the lowest: compounds 2, 1 and 3 (each within the scatter of the next).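

In this assay, this position has now held hydrogen, chloro and amino, and the three compounds are not told apart by their numbers. The earlier pair tested only chloro in place of hydrogen, whereas the new steps bring in a group with a hydrogen-bond donor and a hydrogen-bond acceptor, neither of which chloro has, and both steps stay within the scatter (a 1.3-fold higher number from compound 2 to compound 3 (0.11 log units; within the scatter); a 1.0-fold higher number from compound 1 to compound 3 (0.00 log units; within the scatter)). So far, then, the number has not responded to any of the three groups at this aromatic carbon, though no evidence is available to explain that lack of response.

The compounds shown leave open whether a carboxylic acid, a methoxy group or a longer chain at this position would also stay within the scatter, or whether one of them would finally separate from hydrogen, chloro and amino. They also leave open what a change elsewhere on the shared core would do, since all three compounds differ only at this one aromatic carbon.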